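The source may hold more compounds than are shown below. What is called first, only, known or untested is meant among the compounds shown, and "the series" means these compounds.

Measured so far in a functional assay on MOLT-4 cells (Homo sapiens); a higher number here means a weaker inhibitor, a lower number a stronger inhibitor:
Compound 1 `CCCCCCCCc1cn([C@@H]2O[C@H](CO)[C@@H](O)[C@H]2O)nn1` gives 50000 nM in this assay.
Compound 3 `COc1ccc(-c2cn([C@@H]3O[C@H](CO)[C@@H](O)[C@H]3O)nn2)cc1` gives 36000 nM in this assay.
Compound 2 `CC(O)c1cn([C@@H]2O[C@H](CO)[C@@H](O)[C@H]2O)nn1` gives only a limit in this assay, > 200000 nM.

Compound 2 thus stands without a number of its own: its value is the limit, (the limit of > 200000 nM in this assay, at which 1 of the 3 values shown sits). Compound 4 `OC[C@H]1O[C@@H](n2cc(-c3ccc(F)cc3)nn2)[C@H](O)[C@@H]1O` differs from compound 2 in one place, (4-fluorophenyl in place of 1-hydroxyethyl on an aromatic carbon), that is, 4-fluorophenyl in place of 1-hydroxyethyl on an aromatic carbon. Going by the values given here, no measured pair covers this exact exchange. Compound 3 carries a related aryl group on the same carbon and gives 36000 nM in this assay, which guides the expectation. From the limit of compound 2, a step to a lower number is expected, an at least 5.0-fold lower number from compound 2 to compound 4 (0.69 log units; beyond the scatter). Compound 4 is therefore estimated at 40000 nM, with a range from 15000 nM to 150000 nM.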

Compound 4, half-maximal inhibitory concentration: 171000 nM
The estimate for compound 4 lay 4.3-fold (0.63 log units) below the measured number; the whole stated range lies below it.
By their numbers in this assay, from the lowest: compounds 3 and 1 (each within the scatter of the next); then compound 4. At a limit, above all of these: compound 2.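

In this assay, an aryl group on this aromatic carbon does not settle the number by itself: fluoro in place of methoxy gives a 4.8-fold higher number from compound 3 to compound 4 (0.68 log units; beyond the scatter). With 4-fluorophenyl in place of 1-hydroxyethyl, the data give an at least 1.1-fold lower number from compound 2 to compound 4 (0.06 log units; that floor lies within the scatter), so no gain beyond the scatter can be claimed for this exchange. Compound 2 has only a limit, not a number: the limit of > 200000 nM in this assay, at which 1 of the 4 values shown sits.

The compounds shown leave open how an amine or a carboxylic acid on this carbon would read. They also leave open whether ethoxy in place of methoxy on the aryl group would keep the number of compound 3.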